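Adding ethyl to the chain of compound 2

A few compounds are considered here, and "the series" means these few. Any claim that something is new, unique, unknown or untested is made for them only; others in the source may bear on it.

Values in an ADME assay on cells (Hepatocyte, Homo sapiens) for metabolic stability, read by LC-MS, with a stated time of 180 min, tested at 1 uM (on this read-out lower numbers stand for slow clearance and higher numbers for fast clearance), each one a limit:

- Compound 1 `CC(C(=O)O)c1nn(Cc2cn3cc(OCC4CC4)c(Cl)cc3n2)c2ccccc2c1=O` has the limit < 8.34 mL/min/kg
- Compound 2 `O=C(O)Cc1nn(Cc2cn3cc(OCC4CC4)c(Cl)cc3n2)c2ccccc2c1=O` has the limit < 6.67 mL/min/kg
- Compound 3 `C[C@H](C(=O)O)n1nc(Cn2cc3cc(OCC4CC4)c(Cl)cc3n2)c2ccccc2c1=O` has the limit < 10 mL/min/kg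

In this assay compound 2 has < 6.67 mL/min/kg, which is a limit and not a number. Compound 4 `CCC(C(=O)O)c1nn(Cc2cn3cc(OCC4CC4)c(Cl)cc3n2)c2ccccc2c1=O` differs from it by ethyl in place of hydrogen on a saturated chain carbon bound to an aromatic carbon and a carbonyl carbon. Among the measured compounds shown here, one measured step bears on this change, a step that the two limits leave unreadable from compound 1 to compound 2, at the same place, and its size cannot be read. With no readable size to go on, the estimated step of an at least 1.0-fold higher number from compound 2 to compound 4 (0.02 log units; that floor lies within the scatter) is expected to stay within the scatter, in no particular direction. For compound 4 the estimated clearance is 7 mL/min/kg, with an expected range from 4 mL/min/kg to 14 mL/min/kg, and the result may well arrive as a limit.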

Compound 4, clearance: < 8.34 mL/min/kg
Compound 4 ended at the assay's limit; the forecaster's own chance of this, stated with the estimate: 65%; the middle value lies beyond the limit too.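

Among the compounds shown here, compound 1, compound 2 and compound 4 each give only a limit in this assay, not a number, and no step among them can be read. From the compounds shown here alone, whether ethyl in place of hydrogen changes clearance at all remains open.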